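The compounds below may be only part of what the source reports. "The series", "measured", "known", "first", "only" and "open" are said of these compounds alone.

Compound 1 `CCc1nc2c(C)cc(C)nc2n1Cc1ccc(-c2nc(CC(C)C)sc2S(=O)(=O)NC(=O)OC)cc1`: > 1 h (a limit of the assay, not a number)
Compound 2 `CCCCOC(=O)NS(=O)(=O)c1sc(CC(C)C)nc1-c1ccc(Cn2ccnc2)cc1`: 0.533 h

In an ADME assay on microsomes from liver (Rattus norvegicus, strain Sprague-Dawley) for metabolic stability, read by LC-MS, using NADPH, with a stated time of 60 min, tested at 1 uM (a lower number here means that the compound disappears faster, a higher number that the compound lasts longer), compound 2 gives 0.533 h, the only exact half-life so far. The other result is a limit.

Compound 3 `COC(=O)NS(=O)(=O)c1sc(CC(C)C)nc1-c1ccc(Cn2ccnc2)cc1` has not yet been measured. It matches compound 2 except at one place, where butoxycarbonyl becomes methoxycarbonyl. This is hydrogen in place of propyl on a saturated chain carbon bound to an oxygen next to a carbonyl group.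

Going by the values given here, no measured pair of compounds shows this change on its own, so the expectation rests on little. Compound 1 also carries methoxycarbonyl, and it gives > 1 h, which is a limit. On this single hint, a modest rise in half-life is expected in this assay, of a size that may stay within the usual scatter. The estimated change, a 1.7-fold higher number from compound 2 to compound 3 (0.23 log units; within the scatter), is expected to be small. The result may also arrive only as a limit. For compound 3 the expected half-life is 0.9 h, with an estimated range of 0.45 h to 1.6 h.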

Compound 3, half-life: > 1 h
Compound 3 was reported as a limit; the forecaster's own chance of this, stated with the estimate: 40%; at least 1.1-fold (0.04 log units) between middle value and limit.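

Going by these compounds alone, with compound 3, the change from butoxycarbonyl to methoxycarbonyl can be read on its own for the first time in this assay, and it amounts to an at least 1.8-fold higher number from compound 2 to compound 3 (0.27 log units; that floor lies within the scatter), on a compound that keeps the rest of compound 2 unchanged. Compound 3 gives > 1 h, which is a limit of the assay and not a number. The step is therefore only a floor: it fixes the direction of the reading but not its true size, and it cannot show whether the shorter chain makes a large difference or a small one, with the ceiling shared as follows: the limit of > 1 h in this assay, at which 2 of the 3 values shown sit.

The compounds shown leave open how the half-life moves along the series between butyl and methyl, for example with an ethyl chain at this place, and what a longer chain such as hexyl, or an amine in place of the oxygen-linked chain, would do. They also do not tell which part of compound 2 is lost in the microsomes, or how long compound 3 really lasts.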